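The source may report more compounds than this note shows. Statements on the series, on what has been measured and on what is new or still open speak of the compounds shown alone.

Values measured so far in an ADME assay on cells (Hepatocyte, Mus musculus) for metabolic stability, with a stated time of 30 min; a lower number here means that less of the compound is left, a higher number that more of the compound is left:
- compound 1 `O=C(OC1CCC(CN2CCN(c3cc(=O)c4cc(C(F)(F)F)cc([N+](=O)[O-])c4s3)CC2)CC1)c1ccccc1` gives 68.1%
- compound 2 `O=c1cc(N2CCN(CC3CCC(NS(=O)(=O)c4ccccc4)CC3)CC2)sc2c([N+](=O)[O-])cc(C(F)(F)F)cc12` gives 95.3%
- compound 3 `O=c1cc(N2CCN(CC3CCCCC3)CC2)sc2c([N+](=O)[O-])cc(C(F)(F)F)cc12` gives 80.6%

Compound 3 stands second highest of the three, with compound 1 lower and compound 2 higher, both beyond the scatter. Compound 4 `COc1ccc(C(=O)OC2CCC(CN3CCN(c4cc(=O)c5cc(C(F)(F)F)cc([N+](=O)[O-])c5s4)CC3)CC2)cc1` carries ((4-methoxyphenyl)carbonyl)oxy in place of hydrogen on a saturated ring carbon. The most direct evidence is a number 12.5 percentage points higher from compound 1 to compound 3 (beyond the scatter) on removing benzoyloxy, a modest step to be read in reverse here. The step of a number 14.7 percentage points lower from compound 2 to compound 3 (beyond the scatter) concerns a different group and bears less directly. Within the data shown here, no measured compound carries the 4-methoxyphenyl part. A fall of similar size is expected, with a number 14.6 percentage points lower from compound 3 to compound 4 (beyond the scatter) as the estimated step. The estimate for compound 4 is 66% in an expected range of 53% to 79% for this read-out.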

Compound 4, percent of the compound remaining: 31%
The estimate for compound 4 lay 35 percentage points above the measured number; measured number outside the range, below it.
By their numbers in this assay, from the lowest: compound 4; then compound 1; then compound 3; then compound 2.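

In this assay, the aryl part of the ester matters as well as the ester itself: methoxy in place of hydrogen on an aromatic carbon gives a number 37.1 percentage points lower from compound 1 to compound 4 (beyond the scatter) on its own. Measured against hydrogen, ((4-methoxyphenyl)carbonyl)oxy on the saturated ring carbon gives a number 49.6 percentage points lower from compound 3 to compound 4 (beyond the scatter) and so costs far more than benzoyloxy, while against (phenylsulfonyl)amino it gives a number 64.3 percentage points lower from compound 2 to compound 4 (beyond the scatter) as the widest step in the series. Nothing measured on these compounds accounts for the fall.

Open, on these data alone, is whether a hydroxyl or an amide on this saturated ring carbon would keep the number near that of compound 3. Also open, as far as these compounds go, is whether a chloro group in place of the methoxy would bring the same fall.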